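Adding an acyl group to compound 1's ring nitrogen

The source may report more compounds than this note shows. Statements on the series, on what has been measured and on what is new or still open speak of the compounds shown alone.

In a functional assay on NCI-H1975 cells (Homo sapiens) for antiproliferative activity (on this read-out lower numbers stand for stronger inhibition and higher numbers for weaker inhibition), compound 1 `Cc1c2c(n3c1CCNC[C@@H](C)[C@H](C)Nc1cc-3ccc1C(N)=O)CC(C)(C)CC2=O` gives 27 nM. Compound 2 `Cc1c2c(n3c1CCCN(C(=O)CO)[C@@H](C)[C@H](C)Nc1cc-3ccc1C(N)=O)CC(C)(C)CC2=O` gives 54 nM, so the two values lie within the scatter of each other, and compound 1 has no clear standing apart from compound 2. The next step leads to compound 3 `Cc1c2c(n3c1CCN(C(=O)C1(N)CC1)C[C@@H](C)[C@H](C)Nc1cc-3ccc1C(N)=O)CC(C)(C)CC2=O`, in which (1-aminocyclopropyl)carbonyl replaces hydrogen on an amine nitrogen in a ring of the core of compound 1 ((1-aminocyclopropyl)carbonyl in place of hydrogen on an amine nitrogen in a ring). For the measured compounds named here, no measured pair shows this change on its own, so any expectation in this assay rests on thin evidence. Going by the values given here, with compound 2 at 54 nM as the only comparison, little or no step beyond the scatter is expected, with any drift towards a higher number. The estimated step is a 1.5-fold higher number from compound 1 to compound 3 (0.17 log units; within the scatter). Compound 3 is expected at 40 nM, within an estimated range of 13 nM to 120 nM.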

Compound 3, half-maximal inhibitory concentration: 72 nM
For compound 3 the middle estimate is 1.8-fold (0.26 log units) below the measured one, and the stated range covers the measured number.
By their numbers in this assay, from the lowest: compounds 1, 2 and 3 (each within the scatter of the next, the first and the last beyond it).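

In this assay, for the compounds shown here, (1-aminocyclopropyl)carbonyl in place of hydrogen on the amine nitrogen in a ring gives a 2.7-fold higher number from compound 1 to compound 3 (0.43 log units; beyond the scatter), the first step that can be read at this position. The step is modest and lies beyond the scatter, so this nitrogen accepts the added group with weaker inhibition but without loss of activity in the cells. No measurement shown gives a reason for this step.

From the compounds shown here alone, what stays open is whether the step comes with the carbonyl alone or with the amine and the three-membered ring that it carries. A plain acetyl group on the same nitrogen would separate these two parts, and a methyl group there would show whether the result depends on an acyl group at all.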